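The source may hold more compounds than are shown below. What is called first, only, known or untested is meant among the compounds shown, and "the series" means these compounds.

Measured compounds:
Compound 1 `CCCCCCCc1cccc(N2CCNCC2)n1` — 10 mg/kg
Compound 2 `CCCCCCc1cccc(N2CCNCC2)n1` — 10 mg/kg

Both were tested in a functional assay on the whole organism with Mus musculus as the target, in the maximal electroshock model, with a stated time of 120 min; a lower number here means that less compound is needed, a higher number that more compound is needed for the effect. Compound 1 stands level with compound 2 at the digits shown: the step of no change at the digits printed from compound 1 to compound 2 (within the scatter), which shortens the saturated chain by one carbon, is within the scatter of the assay. Compound 3 `CCCCCCCc1cccc(N2CCN(C)CC2)n1` has not been tested. It differs from compound 1 in one place: methyl in place of hydrogen on an amine nitrogen in a ring. Among the measured compounds shown here, the only measured step, from compound 1 to compound 2, concerns the chain and not the ring nitrogen, so it bears on this change only loosely, and it was itself flat. Nothing in the two measured compounds points to a shift in either direction. The step of no change at the digits printed from compound 1 to compound 3 (within the scatter) is therefore expected to stay within the scatter. Compound 3 is estimated at 10 mg/kg, in a range from 5 mg/kg to 25 mg/kg.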

Compound 3, minimum effective dose: 30 mg/kg
Compound 3: the middle estimate sits 3.0-fold (0.48 log units) below what was measured; measured number outside the range, above it.
By their numbers in this assay, from the lowest: compounds 1 and 2 (each within the scatter of the next); then compound 3.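

In this assay, methyl in place of hydrogen on the amine nitrogen in the ring gives a 3.0-fold higher number from compound 1 to compound 3 (0.48 log units; beyond the scatter), so more compound is needed for the same effect. The earlier step changed only the length of the saturated chain and stayed within the scatter, so among the compounds shown, this ring nitrogen is the first place where a small change moves the number beyond the scatter. Nothing measured here explains this step.

A single methyl cannot show whether other groups on this nitrogen, such as an ethyl, an acetyl or a benzyl, would give a smaller or a larger step. On these data alone, it also remains open whether the same methyl would have a similar effect on the shorter chain of compound 2.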